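The source may report more compounds than this note shows. Statements on the series, on what has been measured and on what is new or still open speak of the compounds shown alone.

Measured so far in a functional assay on HCT-116 cells (Homo sapiens) for inhibition, read by MTT assay, with a stated time of 72 h; a higher number here means a weaker inhibitor of growth, a lower number a stronger inhibitor of growth:
- compound 1 `O=C(/C=C/c1ccncc1-c1ccc2[nH]ccc2c1)N1CCOCC1` gives "not determined" (no result reported)
- compound 2 `CCOC(=O)/C=C/c1ccncc1-c1ccc2[nH]ccc2c1` gives 4830 nM
- compound 3 `Cn1ncc2cc(-c3cnccc3/C=C/C(=O)N3CCOCC3)ccc21` gives "not determined" (no result reported)

Compound 2 is the only one of the three with a number in this assay, so it cannot be ranked against the other two, and neither of them offers a comparison. Its value therefore serves as the sole anchor for what follows.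

The next compound to be tested is compound 4 `CCOC(=O)/C=C/c1ccncc1-c1ccc2c(ccn2C)c1`, which differs from compound 2 at a single place: methyl in place of hydrogen on an aromatic nitrogen. The change is methyl in place of hydrogen on an aromatic nitrogen, and the rest of the structure stays the same. For the measured compounds named here, no measured pair in this small set shows what such a change does, so the data offer no direct precedent for its size or direction. In the absence of such a precedent, no step beyond the scatter is expected in this assay, and the expectation stays close to compound 2 at 4830 nM.

This estimate corresponds to an expected 1.2-fold lower number from compound 2 to compound 4 (0.08 log units; within the scatter). For compound 4 the estimated value is 4000 nM, with an expected range from 1500 nM to 10000 nM.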

Compound 4, concentration for 50% growth inhibition: 210 nM
The estimate for compound 4 lay 19-fold (1.28 log units) above the measured number; the measured number lies below the stated range.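

In this assay, methyl in place of hydrogen on an aromatic nitrogen gives a 23-fold lower number from compound 2 to compound 4 (1.36 log units; beyond the scatter), a large step well beyond the scatter and toward stronger inhibition of growth. For the compounds shown here, this pair is the first to show that the nitrogen of the five-membered aromatic ring is sensitive to substitution, since the earlier compounds gave no comparison at this place: a change of only 1 heavy atom, with 0 hydrogen-bond donors and 0 hydrogen-bond acceptors entering, is enough to move the number far from that of compound 2. No measurement shown here accounts for why this change has so large an effect. The compounds shown leave open whether the gain is particular to methyl or would persist with a longer chain such as ethyl or propyl, or with a chain ending in an amine, on the same nitrogen. They also leave open whether the same step would appear with the morpholine amide of compound 1 in place of the ethyl ester, as this single pair speaks only for the ester series.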